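A few compounds are considered here, and "the series" means these few. Any claim that something is new, unique, unknown or untested is made for them only; others in the source may bear on it.

Among the three compounds measured so far, compound 3 `CCCn1c(=O)c2nc(-c3cnn(Cc4cccc(Cl)c4)c3)[nH]c2n(CCC)c1=O` stands lowest in an in vitro assay on HEK293 cells for displacement of a labelled ligand from adenosine receptor A2b (Homo sapiens) (a lower number here means a stronger inhibitor, a higher number a weaker inhibitor), giving 18 nM. Compound 1 `CCCn1c(=O)c2nc(-c3cnn(Cc4ccccc4C(F)(F)F)c3)[nH]c2n(CCC)c1=O` gives 37 nM in this assay, and compound 2 `CCCn1c(=O)c2nc(-c3cnn(Cc4c(F)cccc4F)c3)[nH]c2n(CCC)c1=O` gives 390 nM. The step of a 2.1-fold lower number from compound 1 to compound 3 (0.31 log units; beyond the scatter) is modest, while the step of a 22-fold lower number from compound 2 to compound 3 (1.34 log units; beyond the scatter) is large, and the step of an 11-fold higher number from compound 1 to compound 2 (1.02 log units; beyond the scatter) is large as well.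

Compound 4 `CCCn1c(=O)c2nc(-c3cnn(Cc4c(F)cc(F)cc4F)c3)[nH]c2n(CCC)c1=O` has not yet been measured in this assay. It differs from compound 3 in one place: 2,4,6-trifluorophenyl in place of 3-chlorophenyl on a saturated chain carbon bound to an aromatic nitrogen.

The most telling comparison is with compound 2, whose 2,6-difluorophenyl resembles the 2,4,6-trifluorophenyl entering in compound 4. The step of a 22-fold lower number from compound 2 to compound 3 (1.34 log units; beyond the scatter) shows that moving from 2,6-difluorophenyl to 3-chlorophenyl lowers the number a great deal, so the reverse move from 3-chlorophenyl to a fluorinated phenyl of this kind is expected to raise it by a comparable amount. The step of an 11-fold higher number from compound 1 to compound 2 (1.02 log units; beyond the scatter) points the same way, since 2,6-difluorophenyl gave the highest number seen. Within the data shown here, no measured compound carries a 2,4,6-trifluorophenyl, so the added fluorine remains untested.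

Compound 4 is therefore expected to give about 350 nM in this assay, with a plausible range of 100 nM to 1200 nM. This estimate means a step of a 19-fold higher number from compound 3 to compound 4 (1.29 log units; beyond the scatter), expected to be large and beyond the scatter.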

Compound 4, inhibition constant: 650 nM
Beside the measured number, compound 4's estimate is 1.9-fold (0.27 log units) below it, within the range that was stated.
By their numbers in this assay, from the lowest: compound 3; then compound 1; then compounds 2 and 4 (each within the scatter of the next).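

In this assay, among these compounds, the step of a 1.7-fold higher number from compound 2 to compound 4 (0.22 log units; within the scatter) shows that fluoro in place of hydrogen on an aromatic carbon, the one change still untested before this result, has no readable effect on this series. The other two steps, a 36-fold higher number from compound 3 to compound 4 (1.56 log units; beyond the scatter) and an 18-fold higher number from compound 1 to compound 4 (1.24 log units; beyond the scatter), are both large, so 2,4,6-trifluorophenyl joins 2,6-difluorophenyl at the weak end, well apart from 3-chlorophenyl and 2-(trifluoromethyl)phenyl. On a saturated chain carbon bound to an aromatic nitrogen, the two fluorophenyl groups therefore give high numbers and the other two give low numbers, and none of the four compounds goes against this pattern.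

Nothing available here explains why the numbers fall into these two groups. On these data alone, four compounds also cannot show how a plain phenyl, a 3-fluorophenyl or a 3-methoxyphenyl would behave at this place, so it stays open whether the high numbers follow from having several fluorines on the ring or from where those fluorines sit.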